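Aryl hydrazone variation on the shared core, cytotoxicity notes

The source may report more compounds than this note shows. Statements on the series, on what has been measured and on what is new or still open speak of the compounds shown alone.

Measured compounds:
compound 1 `CN(C)CCn1cnnc1-c1cc(Oc2ccc(NC(=O)N/N=C/c3ccc(Cl)cc3Cl)cc2F)ccn1` gives 750 nM in a functional assay on MKN-45 cells (Homo sapiens) for cytotoxicity, read by MTT assay, with a stated time of 72 h; on this read-out higher numbers stand for weaker inhibition and lower numbers for stronger inhibition
compound 2 `CN(C)CCn1cnnc1-c1cc(Oc2ccc(NC(=O)N/N=C/c3c[nH]c4ccccc34)cc2F)ccn1` gives 790 nM in this assay
compound 3 `CN(C)CCn1cnnc1-c1cc(Oc2ccc(NC(=O)N/N=C/c3ccc(O)c(Br)c3)cc2F)ccn1` gives 1860 nM in this assay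

Compound 3 stands at the highest number of the three, with a 2.5-fold higher number from compound 1 to compound 3 (0.39 log units; beyond the scatter) and a 2.4-fold higher number from compound 2 to compound 3 (0.37 log units; beyond the scatter) both beyond the scatter, while compound 1 and compound 2 sit within the scatter of each other.

Compound 4 `CN(C)CCn1cnnc1-c1cc(Oc2ccc(NC(=O)N/N=C/c3ccccc3O[N+](=O)[O-])cc2F)ccn1` differs from compound 3 by 2-(nitrooxy)phenyl in place of 3-bromo-4-hydroxyphenyl on a carbon with a double bond to nitrogen. Within the data shown here, no measured step covers this exact exchange; the only steps that touch the same position are those from compound 3 to the other two aryl groups, each a modest move to a lower number. A modest lower number is therefore expected in this assay, as a 2.1-fold lower number from compound 3 to compound 4 (0.32 log units; beyond the scatter).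

Compound 4 is estimated at 900 nM, with a range of 400 nM to 2500 nM.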

Compound 4, half-maximal inhibitory concentration: 1020 nM
Estimate against measurement, compound 4: 1.1-fold (0.05 log units) below; the measured number falls inside the stated range.
By their numbers in this assay, from the lowest: compounds 1, 2, 4 and 3 (each within the scatter of the next, the first and the last beyond it).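

In this assay the exchange gives a 1.8-fold lower number from compound 3 to compound 4 (0.26 log units; within the scatter) and so does not separate the two groups, although the 2-(nitrooxy)phenyl group has no hydrogen-bond donors and the 3-bromo-4-hydroxyphenyl group has one. Among these compounds, the other new steps, a 1.3-fold higher number from compound 2 to compound 4 (0.11 log units; within the scatter) and a 1.4-fold higher number from compound 1 to compound 4 (0.13 log units; within the scatter), are also within the scatter, so compound 4 is the only compound within the scatter of all the others at this position. No supporting data explain these numbers.

Open, as far as these compounds go, is whether an unsubstituted phenyl group would stay within this band. Also open, from the compounds shown here alone, is whether an aryl group carrying an amine or a carboxylic acid would move beyond it.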